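The source may hold more compounds than are shown below. What is called first, only, known or untested is meant among the compounds shown, and "the series" means these compounds.

Measured in a functional assay, with a stated time of 6 min; a higher number here means a weaker inhibitor, a lower number a stronger inhibitor:
- compound 1 `Fc1ccc(NCn2nc(-c3ccc4c(c3)OCCO4)oc2=S)cc1`: 6480 nM
- compound 2 `FC(F)(F)c1ccccc1NCn1nc(-c2ccc3c(c2)OCCO3)oc1=S`: 9220 nM
- compound 3 `FC(F)(F)c1cc(NCn2nc(-c3ccc4c(c3)OCCO4)oc2=S)cc(C(F)(F)F)c1`: 9320 nM

In this assay, compound 1 at 6480 nM lies within the scatter of both compound 2 and compound 3, so the three values cannot be ranked. The next compound to be tested is compound 4 `S=c1oc(-c2ccc3c(c2)OCCO3)nn1CNc1ccc(Cl)c(Cl)c1`, which keeps the core of compound 1 and makes one change: 3,4-dichlorophenyl in place of 4-fluorophenyl on an amine nitrogen. In words, 3,4-dichlorophenyl stands in place of 4-fluorophenyl on an amine nitrogen.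

For the measured compounds named here, no measured pair differs in one place only, so there is no direct precedent for the size of this step. Going by the values given here, the only guide is that compound 1 at 6480 nM, compound 2 at 9220 nM and compound 3 at 9320 nM stay within the scatter of one another, although their aryl groups differ. No shift beyond the scatter is therefore expected in this assay. The estimate amounts to an expected 1.1-fold lower number from compound 1 to compound 4 (0.03 log units; within the scatter). For compound 4 the estimated value is 6000 nM, with an expected range of 2000 nM to 15000 nM.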

Compound 4, half-maximal inhibitory concentration: 6840 nM
Compound 4: middle estimate off by 1.1-fold (0.06 log units), on the low side; the range from low to high includes it.
By their numbers in this assay, from the lowest: compounds 1, 4, 2 and 3 (each within the scatter of the next).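

For the compounds shown here, until now no pair differed in one place only, so this is the first direct reading of a change on the amine nitrogen. In this assay, 3,4-dichlorophenyl in place of 4-fluorophenyl gives a 1.1-fold higher number from compound 1 to compound 4 (0.02 log units; within the scatter), which shows that this aryl group can carry two chlorine atoms instead of one fluorine without a shift beyond the scatter. No further data accompany this result that could account for it.

The aryl groups shown carry only halogens or trifluoromethyl, so it remains open whether a carboxylic acid or an amine on the ring would shift the number beyond the scatter. On these data alone, it also remains open whether a longer chain in place of the saturated chain carbon would do so.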